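The compounds below may be only part of what the source reports. "The series", "measured", "known", "first", "only" and "open" are said of these compounds alone.

Measured in a functional assay on L1210 cells (Mus musculus) for inhibition; on this read-out lower numbers stand for stronger inhibition and higher numbers for weaker inhibition:

- Compound 1 `C=C1[C@@H](O)[C@H](n2cnc3c(N)nc(N)nc32)O[C@@H]1CO`: > 200000 nM, a limit
- Compound 2 `C=C1[C@@H](O)[C@H](n2cnc3c(O)nc(N)nc32)O[C@@H]1CO`: > 200000 nM, a limit
- Compound 3 `C=C1[C@@H](O)[C@H](n2cnc3c(N)ncnc32)O[C@@H]1CO`: 228000 nM

Within the data shown here, compound 3 gives 228000 nM, the only actual number. The other two results are limits. The next compound to be tested is compound 4 `C=C1[C@@H](O)[C@H](n2cnc3c(O)ncnc32)O[C@@H]1CO`. The change from compound 3 is hydroxy in place of amino on an aromatic carbon.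

Among the measured compounds shown here, the closest precedent is the same exchange of groups in a step that the two limits leave unreadable from compound 1 to compound 2. The other measured change, hydrogen in place of amino, appears as a step that the limit leaves unreadable from compound 1 to compound 3. Neither step yields a size because of the limit of > 200000 nM in this assay, at which 2 of the 3 values shown sit. For the measured compounds named here, the series therefore offers no measured precedent for a shift in either direction, and compound 3 itself sits in the same general region of this assay as those limits. On that basis, no change beyond the usual scatter is expected, and the expected step is a 1.1-fold higher number from compound 3 to compound 4 (0.04 log units; within the scatter). It is also quite likely that the result for compound 4 will be reported only as a limit. If a number is obtained, the estimate for compound 4 is 250000 nM, with an expected range from 120000 nM to 600000 nM.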

Compound 4, half-maximal inhibitory concentration: > 200000 nM
Compound 4 gave a limit, no number; the forecaster's own chance of this, stated with the estimate: 70%; the middle value is on the limit's open side.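

In this assay compound 4 gives > 200000 nM, which is a limit and not a number. The steps to compound 4 from compound 3 and from compound 2 cannot be read, because the result falls at the limit shared across the series: the limit of > 200000 nM in this assay, at which 3 of the 4 values shown sit. The compounds shown leave open whether either exchange on the aromatic carbon changes inhibition at all.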